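The source may report more compounds than this note shows. Statements on the series, on what has been measured and on what is new or still open speak of the compounds shown alone.

Measured so far in a functional assay on MCF7 cells (Homo sapiens) for cytotoxicity, read by MTT assay, with a stated time of 72 h; a lower number here means a stronger inhibitor, a higher number a weaker inhibitor:
compound 1, `Cc1c(C(=O)Nc2ccc(Oc3ccnc4[nH]ccc34)c(F)c2)nnn1-c1ccccc1F`: 420 nM
compound 2, `Cc1c(C(=O)Nc2ccc(Oc3ccnc4[nH]ccc34)cc2)nnn1-c1ccccc1`: 320 nM

Compound 2 has the lowest number of the two; its nearest neighbour is compound 1, whose value sits within the usual scatter of it, so no order between them can be read. The next compound is compound 3, `Cc1c(C(=O)Nc2ccc(Oc3ccnc4[nH]ccc34)cc2)nnn1-c1ccccc1F`, which differs from compound 2 by fluoro in place of hydrogen on an aromatic carbon, ortho to a large group; cut one bond further out, phenyl to 2-fluorophenyl. Within the data shown here, no measured pair shows this change on its own. Compound 1 already carries the 2-fluorophenyl together with a second fluoro, and in this assay compound 1 gives 420 nM, close to compound 2. The change is therefore expected to bring only a small step, none beyond the scatter: a 1.1-fold higher number from compound 2 to compound 3 (0.04 log units; within the scatter). Compound 3 is expected to give 350 nM in this assay, with a range from 150 nM to 800 nM.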

Compound 3, half-maximal inhibitory concentration: 280 nM
For compound 3 the middle estimate is 1.3-fold (0.10 log units) above the measured one; the range from low to high includes it.
By their numbers in this assay, from the lowest: compounds 3, 2 and 1 (each within the scatter of the next).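

In this assay the change from phenyl to 2-fluorophenyl can now be read on its own: the series shows a 1.1-fold lower number from compound 2 to compound 3 (0.06 log units; within the scatter) and so no order between the two compounds. The second fluoro of compound 1 can also now be read alone, with a 1.5-fold lower number from compound 1 to compound 3 (0.18 log units; within the scatter) as the step, so neither single fluoro separates from hydrogen in this read-out. No measurement at hand gives a reason for either step.

Open, going by these compounds, is whether an amine or a methoxy group in place of this fluoro, ortho to a large group, would move the value beyond the scatter. Also open is what a carboxylic acid or a longer chain would do elsewhere on the shared core, as the three compounds shown differ only by fluoro and hydrogen.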